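Chloro for bromo on the thiazole aryl of the phenoxyacetamides

The source may report more compounds than this note shows. Statements on the series, on what has been measured and on what is new or still open speak of the compounds shown alone.

Measured compounds:
- compound 1 `O=C(COc1ccc(F)cc1F)Nc1nc(-c2ccc(Br)cc2)cs1`: 44200 nM
- compound 2 `O=C(COc1ccc(F)cc1F)Nc1nc(-c2ccc(Cl)cc2)cs1`: 26200 nM
- compound 3 `Cc1ccc(OCC(=O)Nc2nc(-c3ccc(Br)cc3)cs2)cc1`: 55800 nM

All three were tested in a functional assay on Ehrlich cells (Mus musculus) for cytotoxicity, read by MTT assay, with a stated time of 48 h; a higher number here means a weaker inhibitor, a lower number a stronger inhibitor. Compound 1 and compound 2 share one core and differ only by chloro in place of bromo on an aromatic carbon. Among the measured compounds shown here, the step of a 1.7-fold lower number from compound 1 to compound 2 (0.23 log units; within the scatter) is the single measured instance of this change. Compound 3 carries the other core; its difference from compound 1 is 4-methylphenyl in place of 2,4-difluorophenyl on an oxygen on a saturated carbon, and the step of a 1.3-fold higher number from compound 1 to compound 3 (0.10 log units; within the scatter) puts the two cores close together in this assay. For the measured compounds named here, compound 3 and compound 2 differ in two places at once, and for that pair no single step is broken down here; their two values simply stand a little further apart than any other pair.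

Compound 4 `Cc1ccc(OCC(=O)Nc2nc(-c3ccc(Cl)cc3)cs2)cc1` is not yet measured. It differs from compound 3 by chloro in place of bromo on an aromatic carbon. The surroundings of the change read the same in both pairs, so this is the same change as from compound 1 to compound 2, now made on the core of compound 3. Going by the values given here, with only one measured instance to go on, the expected step is taken to be of the same size as the earlier one: a 1.7-fold lower number from compound 3 to compound 4 (0.23 log units; within the scatter), set beside a 1.7-fold lower number from compound 1 to compound 2 (0.23 log units; within the scatter), which was itself within the scatter. That expectation rests on compound 1 giving 44200 nM and compound 2 giving 26200 nM in this assay, and on the step of a 1.3-fold higher number from compound 1 to compound 3 (0.10 log units; within the scatter), which puts the two cores close together. On that basis compound 4 is estimated at 33000 nM, with a range from 15000 nM to 80000 nM.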

Compound 4, half-maximal inhibitory concentration: 40600 nM
Estimate against measurement, compound 4: 1.2-fold (0.09 log units) below; the measured number falls inside the stated range.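

In this assay, chloro in place of bromo on the core of compound 3 gives a 1.4-fold lower number from compound 3 to compound 4 (0.14 log units; within the scatter), and the change carries over from the core of compound 1 with no difference that can be told apart: the same change on two cores in this assay, a 1.7-fold lower number (0.23 log units; within the scatter) from compound 1 to compound 2 and a 1.4-fold lower number (0.14 log units; within the scatter) from compound 3 to compound 4, 1.2-fold (0.09 log units) apart, within the scatter of two such steps Read the other way round the square, 4-methylphenyl in place of 2,4-difluorophenyl on the chloro compounds gives a 1.5-fold higher number from compound 2 to compound 4 (0.19 log units; within the scatter), and this swap also reads alike in its two settings: the same change on two cores in this assay, a 1.3-fold higher number (0.10 log units; within the scatter) from compound 1 to compound 3 and a 1.5-fold higher number (0.19 log units; within the scatter) from compound 2 to compound 4, 1.2-fold (0.09 log units) apart, within the scatter of two such steps The four compounds are therefore consistent with simple transfer of either change between these two cores, but each step is itself within the scatter, so agreement between such small steps does not show that either change has a real effect on this read-out, and two cores cannot show how general the transfer is.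

The compounds shown leave open whether the same transfer holds for a methoxy, a nitrile or an amine in place of bromo or chloro on that aromatic carbon. They also leave open what a carboxylic acid or a longer chain would do in place of 4-methylphenyl or 2,4-difluorophenyl on the oxygen.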